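A few compounds are considered here, and "the series" means these few. Any claim that something is new, unique, unknown or untested is made for them only; others in the source may bear on it.

Compound 1, `CCc1cccc2c(=O)c(-c3nn[nH]n3)c[nH]c12`, is the reference point of this account. Going by the values given here, in a functional assay on the whole organism (strain Sprague-Dawley) for inhibition, with Rattus norvegicus as the target (on this read-out higher numbers stand for an effect only at larger amounts of compound and lower numbers for an effect already at smaller amounts), compound 1 gives 0.312 mg/kg, the only numerical value measured so far. Compound 2, `COc1ccc2cc(C(=O)O)cnc2c1`, reaches only a limit of this assay rather than a number, namely (the limit of > 25 mg/kg in this assay, at which 1 of the 2 values shown sits), so compound 2 gives > 25 mg/kg. Among the compounds with values here, no step between two measured compounds that differ in one place is available, so the structural change to the unmeasured compound 3, `O=c1c(-c2nn[nH]n2)c[nH]c2c(F)cccc12`, has no direct precedent. Compound 3 differs from compound 1 in one place: fluoro in place of ethyl on an aromatic carbon. Without a comparable pair to draw on, the expected step from compound 1 to compound 3 is estimated as small, a 1.6-fold higher number from compound 1 to compound 3 (0.20 log units; within the scatter), toward a slightly higher dose but not clearly beyond the scatter. Compound 3 is therefore expected to give about 0.5 mg/kg in this assay, with a range from 0.15 mg/kg to 2.5 mg/kg.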

Compound 3, minimum effective dose: 0.625 mg/kg
Compound 3: the middle estimate sits 1.3-fold (0.10 log units) below what was measured, and the stated range covers the measured number.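

In this assay, fluoro in place of ethyl on this aromatic carbon gives a 2.0-fold higher number from compound 1 to compound 3 (0.30 log units; within the scatter). Going by these compounds alone, this is the first single-place step in the account, and it shows that this position, ortho to a fused ring and meta to a fused ring, can carry either of these two quite different substituents, an alkyl chain or a halogen, without a change that stands out from the scatter. No measurement shown here offers an explanation for this outcome.

Going by these compounds, whether a longer chain such as propyl, a chlorine or an amine on the same carbon would also stay within the scatter of compound 1 remains open. Also open, on these data alone, is how the shared core behaves with only hydrogen at this position, or with fluoro on another carbon of the same ring.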